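This account rests on a few compounds, and the source may have more. Where it says the series, first, only, none or still open, it means among the compounds named here.

Compound 1 `Nc1nc(OCC2CC2)c2ncn(/C=C3/C[C@@H]3CO)c2n1` is one of three compounds that share a core and differ only in the group on the aromatic carbon of the six-membered ring. In a functional assay on HFF cells (Homo sapiens) for cytotoxicity (a higher number here means that more compound is tolerated, a lower number that less compound is tolerated), compound 1 gives 112000 nM, the second highest of the three numbers. Compound 2 `COc1nc(N)nc2c1ncn2/C=C1/C[C@@H]1CO` gives 15800 nM in this assay, and compound 3 `C=CCOc1nc(N)nc2c1ncn2/C=C1/C[C@@H]1CO` gives 220000 nM. The measured steps are a 7.1-fold lower number from compound 1 to compound 2 (0.85 log units; beyond the scatter), a 2.0-fold higher number from compound 1 to compound 3 (0.29 log units; within the scatter) and a 14-fold higher number from compound 2 to compound 3 (1.14 log units; beyond the scatter).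

Compound 4 `Nc1nc(NC2CC2)c2ncn(/C=C3/C[C@@H]3CO)c2n1` differs from compound 1 in one place: cyclopropylamino in place of cyclopropylmethoxy on an aromatic carbon. For the measured compounds named here, none of the measured steps touches the atom that joins the group to the ring; all of them exchange the group on the saturated chain carbon bound to the oxygen. Going by the values given here, they show only that changes at this position can move the number from within the scatter up to a large amount, in either direction. For compound 4 the number in this assay is therefore expected to stay near that of compound 1, with a broad range, the expected step being a 1.1-fold lower number from compound 1 to compound 4 (0.05 log units; within the scatter). The estimate for compound 4 is 100000 nM, expected between 25000 nM and 400000 nM.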

Compound 4, half-maximal cytotoxic concentration: 213000 nM
Compound 4: the middle estimate sits 2.1-fold (0.33 log units) below what was measured; the range from low to high includes it.
By their numbers in this assay, from the lowest: compound 2; then compounds 1, 4 and 3 (each within the scatter of the next).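

This is the first change shown at the atom that joins the group to the ring: in this assay, cyclopropylamino in place of cyclopropylmethoxy gives a 1.9-fold higher number from compound 1 to compound 4 (0.28 log units; within the scatter), so swapping the oxygen link for a nitrogen link, with the chain shortened as well, leaves the number within the scatter. Cyclopropylamino in place of allyloxy is likewise within the scatter, with a 1.0-fold lower number from compound 3 to compound 4 (0.01 log units; within the scatter). Cyclopropylamino in place of methoxy gives a 13-fold higher number from compound 2 to compound 4 (1.13 log units; beyond the scatter), which is beyond the scatter, so compound 2 remains the only one of the four that stands apart.

Nothing available explains why the numbers fall this way. As far as these compounds go, it remains open whether methylamino, the nitrogen-linked counterpart of methoxy, would stand with compound 2 or with compound 4, and how a longer chain on the nitrogen would behave.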